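A few compounds are considered here, and "the series" means these few. Any claim that something is new, unique, unknown or untested is made for them only; others in the source may bear on it.

Measured so far in an ADME assay on microsomes from liver (Homo sapiens) for metabolic stability, with a stated time of 30 min; a higher number here means that more of the compound is left, a lower number that less of the compound is left:

- compound 1 `COc1nc2c(cc1Cc1cccc(Cl)c1F)c(=O)c(C(=O)O)cn2[C@H](CO)C(C)(C)C` gives 82%
- compound 2 `CCOc1nc2c(cc1Cc1cccc(Cl)c1F)c(=O)c(C(=O)O)cn2[C@H](CO)C(C)(C)C` gives 84%
- compound 3 `COc1nc2c(cc1Nc1ccc(F)cc1)c(=O)c(C(=O)O)cn2[C@H](CO)C(C)C` gives "not determined" (no result reported)

Compound 3 has no place on this scale, since its entry reads "not determined" (no result reported) and offers no number to start from. Going on to compound 4 `COc1nc2c(cc1NCc1ccc(F)cc1F)c(=O)c(C(=O)O)cn2[C@H](CO)C(C)C` puts 2,4-difluorobenzyl in place of 4-fluorophenyl on a nitrogen on an aromatic ring.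

Among the compounds with values here, only one measured step exists, and it stays within the scatter: a number 2 percentage points higher from compound 1 to compound 2 (within the scatter). It concerns methyl in place of hydrogen on a saturated chain carbon bound to an oxygen on an aromatic ring, a different change from this one, so it bears on this step only weakly. With no starting number, no size or direction of step can be expected in this assay.

The estimate therefore leans on the general level of the nearest measured compounds, compound 1 at 82% and compound 2 at 84%. Both differ from compound 4 in more than one group, so the range stays wide and reaches well downward. For compound 4 the expected value is an estimated 75%, within a range from 50% to 92%.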

Compound 4, percent of the compound remaining: 87%
Compound 4: middle estimate off by 12 percentage points, on the low side; the measured number falls inside the stated range.
By their numbers in this assay, from the lowest: compounds 1, 2 and 4 (each within the scatter of the next).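

In this assay, within the data shown here, compound 3 reads "not determined" (no result reported) and compound 4 gives 87%, so no step between them can be read. Going by these compounds, what 2,4-difluorobenzyl in place of 4-fluorophenyl does to this number stays open. No supporting evidence bears on this result.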